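Working notes: chloro to nitro exchange and cell toxicity

A few compounds are considered here, and "the series" means these few. Any claim that something is new, unique, unknown or untested is made for them only; others in the source may bear on it.

Measured so far:
Compound 1 `O=C(COc1cccc2ccccc12)N/N=C/c1ccc(Cl)cc1` gives 100 ug/mL in an ADME assay on HEL cells (Homo sapiens) for cytotoxicity; on this read-out higher numbers stand for lower toxicity in this test and lower numbers for higher toxicity in this test.
Compound 2 `O=C(COc1cccc2ccccc12)N/N=C/c1ccc([N+](=O)[O-])cc1` gives 14.2 ug/mL in this assay.
Compound 3 `O=C(COc1cccc2ccccc12)N/N=C/c1ccccc1Cl` gives 62.7 ug/mL in this assay.

The three share one core and differ only in the aromatic substituent. The exchange nitro in place of chloro on an aromatic carbon gave a 7.0-fold lower number from compound 1 to compound 2 (0.85 log units; beyond the scatter). The rearrangement 2-chlorophenyl in place of 4-chlorophenyl on a carbon with a double bond to nitrogen gave a 1.6-fold lower number from compound 1 to compound 3 (0.20 log units; within the scatter), so compound 1 and compound 3 are not separated in this assay.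

Compound 4 `O=C(COc1cccc2ccccc12)N/N=C/c1ccccc1[N+](=O)[O-]` has not been measured. It differs from compound 3 by nitro in place of chloro on an aromatic carbon. This is the same kind of change as that from compound 1 to compound 2, but the place differs: there the entering group sits para to a large group, here ortho to a large group. For the measured compounds named here, with only one example of this exchange, the expectation rests on the step of a 7.0-fold lower number from compound 1 to compound 2 (0.85 log units; beyond the scatter), and a step of similar direction is expected, a 5.2-fold lower number from compound 3 to compound 4 (0.72 log units; beyond the scatter), with a wider range because the place is not the same. Compound 4 is therefore estimated at 12 ug/mL in this assay, expected between 4 ug/mL and 40 ug/mL.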

Compound 4, half-maximal cytotoxic concentration in the HEL assay: 100 ug/mL
For compound 4 the middle estimate is 8.3-fold (0.92 log units) below the measured one; measured number above the stated range.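

In the HEL assay the exchange gives a 1.6-fold higher number from compound 3 to compound 4 (0.20 log units; within the scatter), so compound 3 and compound 4 are not separated, and nitro in place of chloro does not bring a fixed step with it from one core to the other in this series. Set side by side, the two outcomes of the same exchange differ: the same change on two cores in the HEL assay, a 7.0-fold lower number (0.85 log units; beyond the scatter) from compound 1 to compound 2 and a 1.6-fold higher number (0.20 log units; within the scatter) from compound 3 to compound 4, 11-fold (1.05 log units) apart, beyond the scatter of two such steps. For the compounds shown here, with a single pair on each core, this shows that the step from one pair cannot be carried over to the other, but it does not show what sets the gap, and the only further reading, in a physicochemical assay for lipophilicity, measured as octanol-water partition (a higher number here means a more lipophilic compound, a lower number a more polar compound), cannot by itself link lipophilicity to the cell read-out: the measured partition coefficient of compound 3, 4.54, and of compound 4, 3.97, a number 0.57 log units lower (beyond the scatter). In the physicochemical assay compound 3 gives 4.54 and compound 4 gives 3.97.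

On these data alone, it remains open whether the gap follows the place of the entering group or some other difference between the two pairs. As far as these compounds go, it also remains open how an amine, a carboxylic acid or a methoxy group in place of chloro would behave on either core.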